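Side-chain trimming from compound 1 to compound 4

The compounds below may be only part of what the source reports. "The series", "measured", "known", "first", "only" and "open" are said of these compounds alone.

In a functional assay on the whole organism (strain Swiss) with Mus musculus as the target, in the maximal electroshock model, with a stated time of 0.25 h, at a dose of 300 mg/kg by the intraperitoneal route (on this read-out higher numbers stand for a stronger effect at the one dose given and lower numbers for a weaker effect), compound 1 `COCC(C(=O)N1CCN(c2cccc(C(F)(F)F)c2)CC1)N1C(=O)CCC1=O` gives 25%. Compound 3 `CCC(C(=O)N1CCN(c2ccccc2C(F)(F)F)CC1)N1C(=O)CCC1=O` gives 25%, level with compound 1 at the digits shown, and the two together are the highest of the three numbers. Compound 2 `CCC(C(=O)N1CCN(c2ccc(F)cc2)CC1)N1C(=O)CCC1=O` gives 0%, which lies below compound 1 by more than the scatter. For the measured compounds named here, no two measured compounds differ in a single place, so no step can be read from the measured set. Compound 4 `CC(C(=O)N1CCN(c2cccc(C(F)(F)F)c2)CC1)N1C(=O)CCC1=O` differs from compound 1 by hydrogen in place of methoxy on a saturated chain carbon, two bonds along the chain from an amide-type nitrogen in a ring and a carbonyl carbon. With nothing measured to lean on, the step of a number 5 percentage points lower from compound 1 to compound 4 (within the scatter) in this assay is expected to be small, within the scatter in either direction. Compound 4 is estimated at 20%, with a range from 0% to 45%.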

Compound 4, a percentage reported as activity, at one dose (the size of the read-out at that dose, not a potency): 75%
Estimate against measurement, compound 4: 55 percentage points below; measured number above the stated range.
By their numbers in this assay, from the lowest: compound 2; then compounds 1 and 3 (each within the scatter of the next); then compound 4.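

In this assay, for the compounds shown here, hydrogen in place of methoxy on this saturated chain carbon gives a number 50 percentage points higher from compound 1 to compound 4 (beyond the scatter) and is the first single-place step, so the read-out is sensitive to what this position carries. Cut one bond further out, the same difference reads methoxymethyl to methyl. Nothing available accounts for the size of this step.

Open, on these data alone, is whether a propyl chain, a hydroxymethyl group or an amine at this carbon would hold the higher read-out. Also open, as far as these compounds go, is whether the step persists at other doses.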